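A few compounds are considered here, and "the series" means these few. Any claim that something is new, unique, unknown or untested is made for them only; others in the source may bear on it.

For the measured compounds named here, compound 1 `COc1cc(/C=N/Nc2nc(-c3ccc(F)c(F)c3)cs2)cc(Br)c1OC` stands as the lower of the two numbers measured so far in a functional assay on HepG2 cells (Homo sapiens) for inhibition, read by MTT assay, with a stated time of 48 h (on this read-out higher numbers stand for weaker inhibition and lower numbers for stronger inhibition), where compound 1 gives 22400 nM. Going by the values given here, the only other measured compound, compound 2 `COc1cc(/C=N/Nc2nc(-c3ccc(F)c(F)c3)cs2)c(Br)c(Br)c1OC`, gives 49700 nM in this assay, and the single measured step is a 2.2-fold higher number from compound 1 to compound 2 (0.35 log units; beyond the scatter). Compound 3 `COc1cc(/C=N/Nc2nc(-c3ccccc3)cs2)cc(Br)c1OC` has not yet been measured in this assay. It differs from compound 1 by phenyl in place of 3,4-difluorophenyl on an aromatic carbon. Among the compounds with values here, the one measured step concerns bromo in place of hydrogen on the other aromatic ring and does not bear on this exchange, so nothing measured here speaks to replacing the 3,4-difluorophenyl with phenyl on the five-membered ring. Within the data shown here, with no step that bears on the change, the expected step of a 1.1-fold higher number from compound 1 to compound 3 (0.05 log units; within the scatter) is one of no size beyond the scatter, in no firm direction, and the range placed around it is kept wide to reflect that. Compound 3 is therefore estimated to give about 25000 nM in this assay, with a range from 8000 nM to 80000 nM.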

Compound 3, half-maximal inhibitory concentration: 68300 nM
For compound 3 the middle estimate is 2.7-fold (0.44 log units) below the measured one; the measured number falls inside the stated range.
By their numbers in this assay, from the lowest: compound 1; then compounds 2 and 3 (each within the scatter of the next).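

Replacing 3,4-difluorophenyl with phenyl, on the aromatic carbon next to the ring nitrogen of the five-membered aromatic ring, is not a neutral exchange in this assay: it gives a 3.0-fold higher number from compound 1 to compound 3 (0.48 log units; beyond the scatter), a move towards weaker inhibition. For the compounds shown here, this is the first measured sign that the group at this position bears on the read-out, as the earlier step concerned only a bromo on the other aromatic ring. Within this one pair, the 3,4-difluorophenyl goes with the stronger inhibition, although nothing available explains why the number moves with this change.

A single pair cannot show whether both fluorine atoms are needed for this difference, or whether a phenyl carrying one fluoro, a chloro, a methoxy or an amine would sit nearer to compound 1 or to compound 3. It also leaves open whether the same exchange would give a step of similar size on the dibromo core of compound 2, and whether any group at this position would take the number below that of compound 1.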